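Replacing trifluoromethyl with methyl at the solubility limit

This account rests on a few compounds, and the source may have more. Where it says the series, first, only, none or still open, it means among the compounds named here.

Measured in a physicochemical assay for solubility, in phosphate buffer, at pH 7.4 (a higher number here means a more soluble compound, a lower number a less soluble compound), each value being a limit and not a number:
Compound 1 `CCOC(=O)c1c(-c2ccc(Cl)cc2)[nH]c2cccc(OC)c2c1=O`: > 100000 nM
Compound 2 `CCOC(=O)c1c(-c2cccc(F)c2)[nH]c2cccc(OC)c2c1=O`: > 100000 nM
Compound 3 `CCOC(=O)c1c(-c2cccc(C(F)(F)F)c2)[nH]c2cccc(OC)c2c1=O`: > 100000 nM

Compound 3 stands at > 100000 nM, which is a limit of this assay and not a number. The three measured compounds share one reading: the limit of > 100000 nM in this assay, at which 3 of the 3 values shown sit. Compound 4 `CCOC(=O)c1c(-c2cccc(C)c2)[nH]c2cccc(OC)c2c1=O` is the next to be measured, and it differs from compound 3 as follows: methyl in place of trifluoromethyl on an aromatic carbon. In words, it carries methyl in place of trifluoromethyl on an aromatic carbon.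

Going by the values given here, two measured steps bear on this change. Among the compounds with values here, the first is a step that the two limits leave unreadable from compound 1 to compound 2. The second, which introduced the trifluoromethyl group now leaving, is a step that the two limits leave unreadable from compound 2 to compound 3. Neither has a size that can be read, so they offer no size or direction to carry over, and no step beyond the scatter is expected. The expected step is a step that the limit leaves unreadable from compound 3 to compound 4. Compound 4 is estimated at 120000 nM, with an expected range from 60000 nM to 240000 nM, and a further limit is the likeliest report.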

Compound 4, solubility: > 100000 nM
Compound 4 ended at the assay's limit (the forecaster's own chance of this, stated with the estimate: 85%); the middle value lies beyond the limit too.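

Compound 4 also ends at a limit and not a number in this assay, so no step from compound 1, compound 2 or compound 3 to it can be read: the limit of > 100000 nM in this assay, at which 4 of the 4 values shown sit.

The compounds shown leave open how far the solubility of each lies beyond that limit, and whether these groups differ at all.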